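Working notes on the chain end of compound 2

A few compounds are considered here, and "the series" means these few. Any claim that something is new, unique, unknown or untested is made for them only; others in the source may bear on it.

Compound 1 `CCCn1c(=O)n(C)c(=O)c2c1ncn2CC(N)=O`: in a functional assay (trachea) with Cavia porcellus as the target (on this read-out higher numbers stand for an effect only at larger amounts of compound and lower numbers for an effect already at smaller amounts), compound 1 reaches only a limit, > 100000 nM.
Compound 2 `CCCn1c(=O)n(C)c(=O)c2c1ncn2CCC#N`: in this assay compound 2 gives 27600 nM.

Among the compounds with values here, compound 2 stands as the only compound with a real number on this assay; the other value is a limit of the assay, not a number, as the limit of > 100000 nM in this assay, at which 1 of the 2 values shown sits, shows for compound 1. One measured step connects the two: an at least 3.6-fold lower number from compound 1 to compound 2 (0.55 log units; beyond the scatter).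

Compound 3 `CCCn1c(=O)n(C)c(=O)c2c1ncn2CCOC` is not yet measured. It differs from compound 2 by methoxy in place of cyano on a saturated chain carbon, two bonds along the chain from an aromatic nitrogen. Within the data shown here, the one measured step concerns a different exchange on the same chain, carbamoyl to cyanomethyl, and it lowered the number by an at least modest amount. Among the measured compounds shown here, no measured step exchanges cyano for methoxy, so that step gives only a loose anchor: changes at this chain end can move this assay by a modest amount, and the direction of the present change is open. For compound 3 a step of modest size at most is expected, most likely toward a somewhat higher number or none beyond the scatter. Compound 3 is estimated at 35000 nM, within 9000 nM to 110000 nM. The expected step is a 1.3-fold higher number from compound 2 to compound 3 (0.10 log units; within the scatter).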

Compound 3, half-maximal effective concentration: 36100 nM
The estimate for compound 3 lay 1.0-fold (0.01 log units) below the measured number, and the stated range covers the measured number.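

In this assay, methoxy in place of cyano on a saturated chain carbon, two bonds along the chain from an aromatic nitrogen, gives a 1.3-fold higher number from compound 2 to compound 3 (0.12 log units; within the scatter), so the two chain ends cannot be separated on this read-out. The second step away from the carbamoyl end, an at least 2.7-fold lower number from compound 1 to compound 3 (0.44 log units; beyond the scatter), lies beyond the scatter, as does an at least 3.6-fold lower number from compound 1 to compound 2 (0.55 log units; beyond the scatter), so the lower number is not confined to the nitrile and is now seen with two different chain ends. Both steps give only a minimum size, as compound 1 has a limit and not a number: the limit of > 100000 nM in this assay, at which 1 of the 3 values shown sits.

On these data alone, whether an amine, a carboxylic acid or a longer chain at this position would separate from compound 2 and compound 3 stays open, as does whether any chain end reaches numbers well away from theirs. As far as these compounds go, the true size of the steps from compound 1 also stays open, and the shared core is the same in all three compounds, so what changes there would do to this read-out cannot be told from them.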